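The source may report more compounds than this note shows. Statements on the series, on what has been measured and on what is new or still open speak of the compounds shown alone.

Compound 2 `c1ccc2sc(SCCCn3ccnc3)nc2c1` is a compound that carries, on a saturated chain with a sulfur at one end, an imidazole at the other. In a functional assay on LNCaP cells (Homo sapiens) for cytotoxicity, read by sulforhodamine B assay, with a stated time of 72 h (on this read-out higher numbers stand for weaker inhibition and lower numbers for stronger inhibition), compound 2 gives 55000 nM. Among the measured compounds shown here, this is the top of the two numbers measured so far, yet the gap to compound 1 `Brc1cccc(OCCCCn2ccnc2)c1`, which in this assay gives 27600 nM, lies within the usual scatter, so the two cannot be told apart on these data. Compound 3 `c1ccc2sc(SCCCCn3ccnc3)nc2c1` differs from compound 2 in one place: (1H-imidazol-1-yl)methyl in place of 1H-imidazol-1-yl on a saturated chain carbon, three bonds along the chain from a sulfur. For the measured compounds named here, no pair of measured compounds shows what lengthening the chain by one carbon does here, and on so small a change nothing beyond the scatter is expected in this assay in either direction. The expected step of a 1.1-fold lower number from compound 2 to compound 3 (0.04 log units; within the scatter) is therefore small. Compound 3 is estimated at 50000 nM, within a range from 20000 nM to 120000 nM.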

Compound 3, half-maximal inhibitory concentration: 54700 nM
The estimate for compound 3 lay 1.1-fold (0.04 log units) below the measured number, and the stated range covers the measured number.
By their numbers in this assay, from the lowest: compounds 1, 3 and 2 (each within the scatter of the next).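

Swapping 1H-imidazol-1-yl for (1H-imidazol-1-yl)methyl on a saturated chain carbon, three bonds along the chain from a sulfur, gives in this assay a 1.0-fold lower number from compound 2 to compound 3 (0.00 log units; within the scatter). Among the compounds shown here, this is the first pair of measured compounds that differ in one place, and it shows that this single change of chain length leaves the number within the scatter; one step like this cannot establish a trend. Nothing measured here offers a reason for this result.

The compounds shown leave open whether a longer chain would move the number beyond the scatter in this cell assay. They also do not show what an amine or a carboxylic acid would do in place of the imidazole.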